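The compounds below may be only part of what the source reports. "The series", "measured", "known", "first", "only" and "open" are said of these compounds alone.

Compound 1 `CCOC(=O)CCCCCOc1cccc(CN(C(=O)c2ccc(-c3cccc4ccccc34)cc2)C(C)C)c1` in an ADME assay on HepG2 cells (Homo sapiens) for cytotoxicity, read by CellTiter-Glo and resazurin assay, with a stated time of 72 h; on this read-out higher numbers stand for an effect only at larger amounts of compound and lower numbers for an effect already at smaller amounts: > 26000 nM, which is a limit of the assay.
Compound 2 `CCOC(=O)CCCCCOc1cccc(CN(C(=O)c2ccc(-c3cccnc3)cc2)C(C)C)c1` in this assay: > 26000 nM, which is a limit of the assay.
Compound 3 `CCOC(=O)CCCCCOc1cccc(CN(C(=O)c2ccc(-c3ccco3)cc2)C(C)C)c1` in this assay: > 26000 nM, which is a limit of the assay.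

Compound 3 therefore stands at the same place as the other two, at the point where the assay stops reporting a number (the limit of > 26000 nM in this assay, at which 3 of the 3 values shown sit). Among the compounds with values here, the steps a step that the two limits leave unreadable from compound 1 to compound 3 and a step that the two limits leave unreadable from compound 2 to compound 3 cannot be sized, and neither can a step that the two limits leave unreadable from compound 1 to compound 2; no measured step gives a readable change for any swap of the group on the aromatic carbon.

Compound 4 `CCOC(=O)CCCCCOc1cccc(CN(C(=O)c2ccc(-c3ccc(C(C)=O)s3)cc2)C(C)C)c1` differs from compound 3 in one place: 5-acetylthiophen-2-yl in place of furan-2-yl on an aromatic carbon. The measured steps that bear on this swap are all unreadable, so no size or direction can be taken from them. Because every value shown sits at the limit of > 26000 nM in this assay, at which 3 of the 3 values shown sit, the expected outcome for compound 4 is again a limit rather than a number, with an estimated step that the limit leaves unreadable from compound 3 to compound 4. The estimate for compound 4 in this assay is 30000 nM, within a range from 10000 nM to 100000 nM.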

Compound 4, half-maximal effective concentration: > 26000 nM
Compound 4 ended at the assay's limit; the forecaster's own chance of this, stated with the estimate: 80%; the middle value is on the limit's open side.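

No step to compound 4 can be read from compound 1, compound 2 or compound 3, because each result is a limit of the assay and not a number: the limit of > 26000 nM in this assay, at which 4 of the 4 values shown sit.

The compounds shown leave open whether swapping this group changes the read-out in this assay at all.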